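Working notes: from compound 2 to compound 3

The compounds below may be only part of what the source reports. "The series", "measured", "known", "first", "only" and "open" are said of these compounds alone.

Compound 1 `CCCCS(=O)(=O)N1CCC2(CC1)OOC1(CCCCC1)OO2`: > 100 ug/mL (a limit)
Compound 2 `COc1ccc(S(=O)(=O)N2CCC3(CC2)OOC2(CCCCC2)OO3)cc1`: > 100 ug/mL (a limit)

In a functional assay on Huh-7 cells (Homo sapiens) for cytotoxicity, read by MTT assay, with a stated time of 72 h (a higher number here means that more compound is tolerated, a lower number that less compound is tolerated), compound 2 gives > 100 ug/mL, which is a limit and not a number. Compound 1 gives > 100 ug/mL, also a limit. Compound 3 `O=S(=O)(c1ccc(F)cc1)N1CCC2(CC1)OOC1(CCCCC1)OO2` has fluoro in place of methoxy on an aromatic carbon, para to a large group: fluoro in place of methoxy on an aromatic carbon.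

Going by the values given here, the only measured step that bears on this change is a step that the two limits leave unreadable from compound 1 to compound 2. Among the compounds with values here, the series so far shows (the limit of > 100 ug/mL in this assay, at which 2 of the 2 values shown sit). That step offers no size to carry over, so no step beyond the scatter is expected in this assay, and no direction is favoured. The expected step is a step that the limit leaves unreadable from compound 2 to compound 3. Compound 3 is most likely to be reported as a limit as well. Compound 3 is estimated at 130 ug/mL, with an expected range of 60 ug/mL to 250 ug/mL.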

Compound 3, half-maximal cytotoxic concentration: > 100 ug/mL
Compound 3 ended at the assay's limit (the forecaster's own chance of this, stated with the estimate: 75%); the middle value is on the limit's open side.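

In this assay compound 3 gives > 100 ug/mL, a limit and not a number. No step can be read among compound 1, compound 2 and compound 3: the limit of > 100 ug/mL in this assay, at which 3 of the 3 values shown sit. The compounds shown leave open how far each tolerated concentration lies past that limit, and whether the sulfonyl substituent affects it.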